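This account rests on a few compounds, and the source may have more. Where it says the series, first, only, none or still open, it means among the compounds named here.

Three measured compounds share one core and differ in the aryl group attached to an amide-type nitrogen and in the group on an aromatic oxygen. Among the measured compounds shown here, compound 3 `COc1cc(-c2nn(-c3cccc(NC(=O)Nc4ccc(Cl)c(C(F)(F)F)c4)c3)cc2-c2ccncc2)ccc1Cl` carries a methoxy on that oxygen; in a functional assay on NCI-H322M cells (Homo sapiens) for inhibition, read by sulforhodamine B assay, with a stated time of 48 h (on this read-out lower numbers stand for stronger inhibition of growth and higher numbers for weaker inhibition of growth), compound 3 gives 13900 nM, the only actual number among the three. Compound 1 `O=C(Nc1cccc(-n2cc(-c3ccncc3)c(-c3ccc(Cl)c(O)c3)n2)c1)Nc1cccc(C(F)(F)F)c1` carries a hydroxy instead, and in this assay compound 1 reaches only the limit of > 32500 nM. Compound 2 `O=C(Nc1cccc(-n2cc(-c3ccncc3)c(-c3ccc(Cl)c(O)c3)n2)c1)Nc1ccc(Cl)c(Cl)c1` likewise sits at the limit of > 32500 nM. For the measured compounds named here, the one measured step, a step that the two limits leave unreadable from compound 1 to compound 2, cannot be sized, as the limit of > 32500 nM in this assay, at which 2 of the 3 values shown sit, shows. Compound 4 `O=C(Nc1cccc(-n2cc(-c3ccncc3)c(-c3ccc(Cl)c(O)c3)n2)c1)Nc1ccc(Cl)c(C(F)(F)F)c1` keeps the aryl group of compound 3 and takes the change (hydrogen in place of methyl on an oxygen on an aromatic ring). Going by the values given here, no measured step alters that oxygen group, so the only guide is that compound 1 and compound 2, both carrying hydroxy, gave no number in this assay, whereas compound 3 with methoxy did. Weaker inhibition of growth is therefore expected from compound 3 to compound 4, a step of a 2.2-fold higher number from compound 3 to compound 4 (0.33 log units; beyond the scatter), with a real chance that only a limit is read. Compound 4 is estimated at 30000 nM, within a range of 10000 nM to 90000 nM.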

Compound 4, concentration for total growth inhibition: 4480 nM
Estimate against measurement, compound 4: 6.7-fold (0.83 log units) above; measured number outside the range, below it.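

In this assay, hydrogen in place of methyl on the aromatic oxygen gives a 3.1-fold lower number from compound 3 to compound 4 (0.49 log units; beyond the scatter), so for this aryl group the hydroxy goes with stronger inhibition of growth than the methoxy, which the limits of the earlier hydroxy compounds could not show. With the hydroxy held in place, the aryl group on the amide-type nitrogen also proves to matter: trifluoromethyl in place of chloro on an aromatic carbon gives an at least 7.2-fold lower number from compound 2 to compound 4 (0.86 log units; beyond the scatter), and chloro in place of hydrogen on an aromatic carbon gives an at least 7.2-fold lower number from compound 1 to compound 4 (0.86 log units; beyond the scatter). These last two steps are minimum sizes rather than exact ones, because one end of each is only a limit of the assay: the limit of > 32500 nM in this assay, at which 2 of the 4 values shown sit.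

From the compounds shown here alone, the gain from methoxy to hydroxy is seen with a single aryl group, so whether it carries over to the aryl groups of compound 1 and compound 2 remains open. Also open, going by these compounds, is how an amine or a carboxylic acid in place of the hydroxy, or a longer chain such as ethoxy on that oxygen, would read in this assay.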